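A few compounds are considered here, and "the series" means these few. Any claim that something is new, unique, unknown or untested is made for them only; others in the source may bear on it.

Measured compounds:
- compound 1, `NNc1nc2ccc(F)cc2s1`: 13.8 ug/mL
- compound 2, `NNc1nc2ccc(Br)cc2s1`: 8.01 ug/mL
- compound 3, `Fc1ccc2nc(Nn3c(-c4ccc(Cl)cc4)nnc3-c3cccnc3)sc2c1`: 92.9 ug/mL

Of the compounds shown here, three have been measured in an ADME assay on MT4 cells (Homo sapiens) for cytotoxicity, read by MTT assay, with a stated time of 5 days; a lower number here means that less compound is tolerated, a higher number that more compound is tolerated. Compound 1 and compound 2 share a small core and differ in one place: bromo in place of fluoro on an aromatic carbon. That change gave a 1.7-fold lower number from compound 1 to compound 2 (0.24 log units; within the scatter). Compound 3 carries a much larger substituent on the same type of core; how its core differs from the core of compound 1 is not broken down here. In this assay compound 3 gives the highest number of the three, beyond the scatter from both compound 1 and compound 2.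

Compound 4, `Clc1ccc(-c2nnc(-c3cccnc3)n2Nc2nc3ccc(Br)cc3s2)cc1`, has not yet been measured. It differs from compound 3 in exactly the same way that compound 2 differs from compound 1: bromo in place of fluoro on an aromatic carbon. Since the step of a 1.7-fold lower number from compound 1 to compound 2 (0.24 log units; within the scatter) stayed within the scatter, compound 4 is expected to land near compound 3, with an estimated step of a 1.4-fold lower number from compound 3 to compound 4 (0.16 log units; within the scatter). Compound 4 is thus estimated at 65 ug/mL in this assay, with a likely range from 30 ug/mL to 130 ug/mL.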

Compound 4, half-maximal cytotoxic concentration: 29.6 ug/mL
Compound 4: the middle estimate sits 2.2-fold (0.34 log units) above what was measured; the whole stated range lies above it.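

Measured in this assay the change of bromo in place of fluoro on an aromatic carbon gave a 3.1-fold lower number from compound 3 to compound 4 (0.50 log units; beyond the scatter) on the larger structure. The two steps for this change cannot be told apart, even though only the new one lies beyond the scatter on its own: the same change on two cores in this assay, a 1.7-fold lower number (0.24 log units; within the scatter) from compound 1 to compound 2 and a 3.1-fold lower number (0.50 log units; beyond the scatter) from compound 3 to compound 4, 1.8-fold (0.26 log units) apart, within the scatter of two such steps. Among the compounds shown here, the pair of results is therefore consistent with the change carrying over between these two cores with a similar size, but it rests on only two matched pairs, so it does not fix one shared size, does not explain the step and says nothing about any other core.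

The compounds shown leave open how a group other than fluoro or bromo, such as a methoxy group or an amine, would read at this same place on the shared core. They also leave open whether the step would hold if the chloro group or the pyridine ring of compound 3 and compound 4 gave way to something else, such as a carboxylic acid.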